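The compounds below may be only part of what the source reports. "The series", "measured", "known", "first", "only" and "open" are said of these compounds alone.

Working notes on the series, read in a physicochemical assay for solubility, at pH 1.1; a lower number here means a less soluble compound, a higher number a more soluble compound. Compound 1 `CCCN(Cc1ccc(OCCN2C(=O)CCC2=O)c(C)c1)C(CC(=O)O)c1ccc(Cl)cc1` gives 3000000 nM. Compound 2 `Cc1cc(CN(C)C(CC(=O)O)c2ccc(Cl)cc2)ccc1OCCn1c(=O)ccn(C)c1=O` gives 3000000 nM. Compound 3 `CCCN(Cc1ccc(OCCn2c(=O)ccn(C)c2=O)c(C)c1)C(CC(=O)O)c1ccc(Cl)cc1` gives 3000000 nM, level with the other two.

The next structure is compound 4 `CCCN(Cc1ccc(OCCn2c(=O)ccn(C)c2=O)c(OC)c1)C(CC(=O)O)c1ccc(Cl)cc1`, reached by methoxy in place of methyl on an aromatic carbon. This is methoxy in place of methyl on an aromatic carbon, ortho to a large group and meta to a large group.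

Among the compounds with values here, no measured step touches this aromatic carbon, so the evidence is indirect. The exchange of groups on the saturated chain carbon gave no change at the digits printed from compound 1 to compound 3 (within the scatter). Ethyl in place of hydrogen on the saturated chain carbon bound to the amine nitrogen gave no change at the digits printed from compound 2 to compound 3 (within the scatter). Neither step left the scatter, and nothing measured points to a direction for the new change, so no shift beyond the scatter is expected in this assay. The expected step is no change at the digits printed from compound 3 to compound 4 (within the scatter). For compound 4 the estimated value is 3000000 nM, with an expected range from 1500000 nM to 4000000 nM.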

Compound 4, solubility: 3000000 nM
Estimate against measurement, compound 4: no gap at the digits printed; measured number inside the range.
By their numbers in this assay, from the lowest: compounds 1, 2, 3 and 4 (each within the scatter of the next).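

Read in this assay, methoxy in place of methyl on the aromatic carbon, ortho to a large group and meta to a large group, gives no change at the digits printed from compound 3 to compound 4 (within the scatter). Within the data shown here, this is the only measured step at this aromatic carbon, and it shows that the exchange of methyl for methoxy there, on the core of compound 3, stays within the scatter, as the steps on the saturated chain carbons did. No measurement shown gives a reason for this result.

From the compounds shown here alone, whether an amine, a carboxylic acid or an ethoxy group on this aromatic carbon would also stay level remains open. With compounds 1, 2, 3 and 4 all within the scatter of one another, the series does not yet show which change, at this carbon or elsewhere, would move the number in this assay.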